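Opening a ring amine to an amino group on the amide

The source may report more compounds than this note shows. Statements on the series, on what has been measured and on what is new or still open speak of the compounds shown alone.

Measured compounds:
- compound 1, `CC#CC(CC(=O)O)c1ccc(OCc2ccc(C(=O)N3CCCc4ccccc43)s2)cc1`, 80 nM in a functional assay on HEK293 cells for agonist activity at Free fatty acid receptor 1 (Homo sapiens), read by fluorescence and calcium flux; on this read-out lower numbers stand for an effect already at smaller amounts and higher numbers for an effect only at larger amounts of compound
- compound 2, `CC#CC(CC(=O)O)c1ccc(OCc2ccc(C(=O)N3CCc4ccccc4C3)s2)cc1`, 57 nM in this assay

Going by the values given here, compound 2 and compound 1 sit within the scatter of each other in this assay, so neither can be called the more potent; the step of a 1.4-fold lower number from compound 1 to compound 2 (0.15 log units; within the scatter) is the only measured step here.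

Compound 3, `CC#CC(CC(=O)O)c1ccc(OCc2ccc(C(=O)NC3CCCc4ccccc43)s2)cc1`, has not yet been measured. It differs from compound 2 by (1,2,3,4-tetrahydronaphthalen-1-yl)amino in place of 1,2,3,4-tetrahydroisoquinolin-2-yl on a carbonyl carbon. Among the compounds with values here, the one measured step swapped one ring amine for another; it says little about a change that brings in a hydrogen-bond donor and moves the ring away from the nitrogen. Within the data shown here, with no step that speaks to this change, a modest movement, if any, is expected, with the direction uncertain, as a 1.6-fold higher number from compound 2 to compound 3 (0.20 log units; within the scatter). Compound 3 is therefore estimated at 90 nM, expected between 30 nM and 300 nM.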

Compound 3, half-maximal effective concentration: 109 nM
For compound 3 the middle estimate is 1.2-fold (0.08 log units) below the measured one; measured number inside the range.
By their numbers in this assay, from the lowest: compounds 2, 1 and 3 (each within the scatter of the next).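

Placed on this carbonyl carbon, (1,2,3,4-tetrahydronaphthalen-1-yl)amino brings in a hydrogen-bond donor that neither earlier ring amine has, yet this assay shows a 1.9-fold higher number from compound 2 to compound 3 (0.28 log units; within the scatter) and a 1.4-fold higher number from compound 1 to compound 3 (0.13 log units; within the scatter) and so no difference that can be told from the scatter. The amide at this position can therefore carry an amide hydrogen and a ring set one atom further from the nitrogen and still read alike with the two ring amides, at least for these three compounds. Nothing measured here explains why these groups read alike.

Still open, going by these compounds, is whether a simple open-chain group such as dimethylamino or benzylamino on the same carbonyl carbon would stay within this scatter. Also open, on these data alone, is what a methyl group in place of the amide hydrogen of compound 3 would do.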